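A Small Imidazole in Place of the Carboxyphenyl Arm

A few compounds are considered here, and "the series" means these few. Any claim that something is new, unique, unknown or untested is made for them only; others in the source may bear on it.

Compound 1 `Clc1cc(Cl)cc(CO[C@H]2CCCN(Cc3ccccn3)[C@H]2c2ccccc2)c1` gives > 200000 nM in an assay on isolated protein for activation of cGMP-dependent protein kinase 1 (Homo sapiens), read by ADP-Glo, with stated times of 120 min and 40 min; a higher number here means that more compound is needed for the effect, a lower number that less compound is needed.
Compound 2 `COc1cc(C(=O)O)ccc1CN1CCC[C@H](OCc2cc(Cl)cc(Cl)c2)[C@@H]1c1ccccc1` gives 62000 nM in this assay.

The value for compound 1 is a limit of the assay rather than a number (the limit of > 200000 nM in this assay, at which 1 of the 2 values shown sits). For the measured compounds named here, compound 2 therefore holds the only real number in this set; the one other value is a limit.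

Compound 3 `Clc1cc(Cl)cc(CO[C@H]2CCCN(Cc3ncc[nH]3)[C@H]2c2ccccc2)c1` differs from compound 2 in a single place: 1H-imidazol-2-yl in place of 4-carboxy-2-methoxyphenyl on a saturated chain carbon bound to an amine nitrogen in a ring. Going by the values given here, the one measured step that speaks to this is an at least 3.2-fold lower number from compound 1 to compound 2 (0.50 log units; beyond the scatter), in which pyridin-2-yl was exchanged for 4-carboxy-2-methoxyphenyl and the number fell from a limit to a measurable value. Compound 3 goes the other way in kind, swapping the carboxy-bearing ring for a small five-membered aromatic ring with two nitrogens, closer in size to the pyridin-2-yl of compound 1.

A step of a 2.4-fold higher number from compound 2 to compound 3 (0.38 log units; beyond the scatter) toward a higher number is therefore expected for compound 3, and its value in this assay is estimated at 150000 nM, most likely between 40000 nM and 400000 nM, with a fair chance that only a limit is reported again.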

Compound 3, half-maximal effective concentration: 47000 nM
Compound 3: middle estimate off by 3.2-fold (0.50 log units), on the high side; low and high end bracket the measured number.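

At this position, on a saturated chain carbon bound to an amine nitrogen in a ring, the 4-carboxy-2-methoxyphenyl group of 11 heavy atoms and the 1H-imidazol-2-yl group of 5 cannot be told apart in this assay, with a 1.3-fold lower number from compound 2 to compound 3 (0.12 log units; within the scatter), so neither the carboxylic acid nor the larger ring is needed for a measurable value in this set. The size of the group alone does not settle the matter either, since exchanging one small aromatic ring for another gives an at least 4.2-fold lower number from compound 1 to compound 3 (0.62 log units; beyond the scatter). That step is open on one side, as compound 1 stands at a limit and not at a number: the limit of > 200000 nM in this assay, at which 1 of the 3 values shown sits.

The compounds shown leave open which feature of the 1H-imidazol-2-yl group separates it from pyridin-2-yl, a question that a 1-methylimidazol-2-yl or a pyrazol-3-yl group would help to answer. Also open, going by these compounds, is whether a carboxylic acid carried on the five-membered ring would lower the number further than either group does alone.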